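A few compounds are considered here, and "the series" means these few. Any claim that something is new, unique, unknown or untested is made for them only; others in the source may bear on it.

Measured compounds:
compound 1, `O=C(CCc1cccc2c1B(O)OC2)Nc1ccc(Cl)cc1`: 12000 nM
compound 2, `Cc1ccc(NC(=O)CCc2cccc3c2B(O)OC3)cc1`: 4500 nM
compound 3, `COc1ccc(NC(=O)CCc2cccc3c2B(O)OC3)cc1`: 1700 nM

All three share one core and differ only in the group on the terminal aromatic ring. In a functional assay on HCT-116 cells (Homo sapiens) for antiproliferative activity, read by MTT assay, with a stated time of 72 h (a higher number here means a weaker inhibitor, a lower number a stronger inhibitor), compound 3 gives the lowest number of the three: a 7.1-fold lower number from compound 1 to compound 3 (0.85 log units; beyond the scatter), a 2.6-fold lower number from compound 2 to compound 3 (0.42 log units; beyond the scatter), and the remaining pair moves as a 2.7-fold lower number from compound 1 to compound 2 (0.43 log units; beyond the scatter). Each exchange of that single group has shifted the number modestly but beyond the scatter, so this position is not indifferent.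

Compound 4, `CCOC(=O)c1ccc(NC(=O)CCc2cccc3c2B(O)OC3)cc1`, has not been measured. It differs from compound 3 as ethoxycarbonyl in place of methoxy on an aromatic carbon. Among the compounds with values here, none of the measured steps puts an ethoxycarbonyl in place, so no direct analogue exists; what the series shows is only that the three groups tried span a modest range in this assay, with methoxy at the favourable end. Compound 3 is therefore the anchor, and the expected step of a 2.1-fold higher number from compound 3 to compound 4 (0.31 log units; beyond the scatter) is set modest, with some lean toward a higher number since methoxy is the best of the groups tried. For compound 4 the estimate in this assay is 3500 nM, with a range from 1200 nM to 12000 nM.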

Compound 4, half-maximal inhibitory concentration: > 100000 nM
Compound 4: no number, only a limit; the forecaster's own chance of this, stated with the estimate: 5%; middle value at least 28-fold (1.45 log units) from the limit.
By their numbers in this assay, from the lowest: compound 3; then compound 2; then compound 1. At a limit, above all of these: compound 4.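

Compound 4 gives no number in this assay, only a limit: the limit of > 100000 nM in this assay, at which 1 of the 4 values shown sits.

Among chloro, methyl and methoxy, every exchange at this position stayed modest, so the earlier compounds showed only a graded response to the group on the aromatic carbon para to the large group. Ethoxycarbonyl breaks out of that range: the change from methoxy is large, with an at least 58-fold higher number from compound 3 to compound 4 (1.76 log units; beyond the scatter), the change from methyl is also large, with an at least 22-fold higher number from compound 2 to compound 4 (1.34 log units; beyond the scatter), and even the comparison with chloro, the weakest of the three earlier groups, gives an at least 8.3-fold higher number from compound 1 to compound 4 (0.92 log units; beyond the scatter). A single exchange at this position can therefore take the series from a measurable antiproliferative effect to none within the range of the assay, and the position is far less forgiving than the first three compounds suggested.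

The compounds shown do not separate the contribution of the carbonyl from that of the ethyl chain, so a methyl ester or a carboxylic acid at this position could fall on either side of the result. Also open, going by these compounds, is whether an amine or a longer ether chain in the same place would stay within the modest range or also lose activity.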